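A few compounds are considered here, and "the series" means these few. Any claim that something is new, unique, unknown or untested is made for them only; others in the source may bear on it.

Measured in a functional assay on IMR-32 cells (Homo sapiens) for antiproliferative activity, read by MTT assay; on this read-out lower numbers stand for stronger inhibition and higher numbers for weaker inhibition:
- compound 1 `CC1(C)CCc2cc(C(=O)/C=C/c3ccc(OCc4cn(-c5ccc(Br)cc5)nn4)cc3)c(O)cc2O1`: 69400 nM
- compound 2 `CC(=O)c1ccc(-n2cc(COc3ccc(/C=C/C(=O)c4cc5c(cc4O)OC(C)(C)CC5)cc3)nn2)cc1`: "not active" (no number reported)
- compound 3 `CCc1ccccc1-n1cc(COc2ccc(/C=C/C(=O)c3cc4c(cc3O)OC(C)(C)CC4)cc2)nn1`: "not active" (no number reported)

The series is thin on numbers. Only compound 1 has a single value, and compound 3 shares its entry without a number with compound 2. Compound 3 therefore has no position on the scale, and its record in this assay can only be read as a qualitative result.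

The unmeasured compound 4 `CCCCCCCCn1cc(COc2ccc(/C=C/C(=O)c3cc4c(cc3O)OC(C)(C)CC4)cc2)nn1` keeps the shared core and the triazole-free description of the rest unchanged apart from one group. The change is octyl in place of 2-ethylphenyl on an aromatic nitrogen.

Among the measured compounds shown here, no measured step exists, so the size of this change cannot be calibrated. The three aryl-bearing compounds give no sign of strong activity, with compound 1 at 69400 nM as the only numerical anchor. In this assay, a modest move towards stronger inhibition relative to compound 3 is expected at most, which would leave compound 4 in the same weak region as compound 1. A second result without a number remains a real possibility.

For compound 4 the estimated value is 40000 nM, with an expected range of 12000 nM to 100000 nM.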

Compound 4, half-maximal inhibitory concentration: 7090 nM
Beside the measured number, compound 4's estimate is 5.6-fold (0.75 log units) above it; measured number outside the range, below it.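

In this assay, the group on the aromatic nitrogen of the five-membered aromatic ring with 3 nitrogen can shift the read-out beyond the usual scatter: octyl in place of 4-bromophenyl gives a 9.8-fold lower number from compound 1 to compound 4 (0.99 log units; beyond the scatter). Compound 3 and compound 2 have no number, so their steps to compound 4 cannot be read, but the 2-ethylphenyl of compound 3 and the octyl of compound 4 have the same heavy-atom count, and only compound 4 has a value, so that count alone does not settle the outcome at this position. Nothing available explains why the octyl compound gives the lower number.

From the compounds shown here alone, whether the lower number depends on chain length or simply on the absence of an aromatic ring at this nitrogen remains open, and a butyl group, a longer chain such as dodecyl or a benzyl group would help separate these readings. Going by these compounds, it is also open whether a chain ending in an amine or a carboxylic acid would retain a measurable value in this assay.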